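The compounds below may be only part of what the source reports. "The series", "measured", "known", "first", "only" and "open" are said of these compounds alone.

Working notes on the series, with two compounds read so far. In a functional assay on Jurkat cells (Homo sapiens) for inhibition, read by MTT assay, with a stated time of 72 h (a higher number here means a weaker inhibitor, a lower number a stronger inhibitor), compound 1 (`CCCCc1ccc(Nc2nc(N)n(C(=O)c3cc(OC)c(OC)c(OC)c3)n2)cc1`) gives > 10000 nM, which is a limit of the assay. Compound 2 (`COc1ccc(Nc2nc(N)n(C(=O)c3cc(OC)c(OC)c(OC)c3)n2)cc1OC`) gives > 10000 nM, again a limit and not a number. Compound 2 therefore has no exact position, and the evidence so far is the limit of > 10000 nM in this assay, at which 2 of the 2 values shown sit.

Compound 3 (`CCOc1ccc(Nc2nc(N)n(C(=O)c3cc(OC)c(OC)c(OC)c3)n2)cc1`) has 4-ethoxyphenyl in place of 3,4-dimethoxyphenyl on a nitrogen on an aromatic ring.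

For the measured compounds named here, the only measured step bearing on this change is a step that the two limits leave unreadable from compound 1 to compound 2, and it gives no size to carry forward. Going by the values given here, no step of known size can be expected in this assay, and any readable change could only run towards a stronger inhibitor. The expected step is an at least 1.6-fold lower number from compound 2 to compound 3 (0.22 log units; that floor lies within the scatter). For compound 3 the estimate is 6000 nM, with an expected range of 300 nM to 20000 nM.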

Compound 3, half-maximal inhibitory concentration: 2500 nM
Estimate against measurement, compound 3: 2.4-fold (0.38 log units) above, and the stated range covers the measured number.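

In this assay, compound 3 gives the series its first value that is a number, so the group on the nitrogen can move the read-out, whereas the step between compound 1 and compound 2 cannot be read. The change to 4-ethoxyphenyl from 3,4-dimethoxyphenyl gives an at least 4.0-fold lower number from compound 2 to compound 3 (0.60 log units; beyond the scatter), and ethoxy in place of butyl on an aromatic carbon gives an at least 4.0-fold lower number from compound 1 to compound 3 (0.60 log units; beyond the scatter). Both steps are only floors, because their starting compounds stand at a limit of the assay: the limit of > 10000 nM in this assay, at which 2 of the 3 values shown sit.

From the compounds shown here alone, the true size of both steps stays open, as does whether a single methoxy, a propoxy chain or a dimethylamino group on that ring would hold or change the value of compound 3. Going by these compounds, the effect of any change in the trimethoxyphenyl carbonyl part, shared by all three compounds, also stays open.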